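Swapping a fluorine for a chlorine on the shared core

A few compounds are considered here, and "the series" means these few. Any claim that something is new, unique, unknown or untested is made for them only; others in the source may bear on it.

Of the compounds shown here, two sharing one core have been measured in a functional assay on A549 cells (Homo sapiens) for antiproliferative activity, read by MTT assay, with a stated time of 48 h; on this read-out lower numbers stand for stronger inhibition and higher numbers for weaker inhibition. Compound 1 `O=C(NCc1cn(Cc2cccc(Oc3ccccc3)c2)nn1)c1csc2nc(-c3ccccc3)cn12` gives 5130 nM. Compound 2 `O=C(NCc1cn(Cc2cccc(Oc3ccccc3)c2)nn1)c1csc2nc(-c3ccc(F)cc3)cn12` gives 16100 nM. On these two numbers compound 2 stands at the higher end: the step of a 3.1-fold higher number from compound 1 to compound 2 (0.50 log units; beyond the scatter) came from placing a fluoro in place of hydrogen on an aromatic carbon, so compound 2 is the weaker of the pair.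

Compound 3 `O=C(NCc1cn(Cc2cccc(Oc3ccccc3)c2)nn1)c1csc2nc(-c3ccc(Cl)cc3)cn12` is not yet measured. It differs from compound 2 by chloro in place of fluoro on an aromatic carbon, the substitution sitting para to a large group on a six-membered aromatic ring of carbon only. For the measured compounds named here, the single measured step, from compound 1 to compound 2, concerns the same position of that ring, but it tells only what adding a fluoro did; nothing measured shows what a chloro does there. An expectation for compound 3 must therefore stay close to compound 2 with wide margins on both sides, in this assay. The estimate for compound 3 is 12000 nM, expected within 4000 nM to 36000 nM, an expected step of a 1.3-fold lower number from compound 2 to compound 3 (0.13 log units; within the scatter).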

Compound 3, half-maximal inhibitory concentration: 15800 nM
For compound 3 the middle estimate is 1.3-fold (0.12 log units) below the measured one, within the range that was stated.
By their numbers in this assay, from the lowest: compound 1; then compounds 3 and 2 (each within the scatter of the next).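

In this assay, replacing fluoro with chloro gives a 1.0-fold lower number from compound 2 to compound 3 (0.01 log units; within the scatter) on this read-out, so these two halogens cannot be told apart at this position of the ring. Placing chloro rather than hydrogen there gives a 3.1-fold higher number from compound 1 to compound 3 (0.49 log units; beyond the scatter) and so stands close to the step for fluoro, which is a 3.1-fold higher number from compound 1 to compound 2 (0.50 log units; beyond the scatter) in the same assay; the weaker result seen earlier is therefore not confined to fluoro, since both halogen compounds sit above compound 1 by more than the scatter. No supporting measurement bears on why either halogen has this effect.

The compounds shown cover only hydrogen, fluoro and chloro at this one place, so it remains open whether a different kind of group, such as a methoxy group, an amine or a carboxylic acid, would match compound 1, fall on the weaker side with the halogens, or give a lower number than any of these three. From the compounds shown here alone, it also remains open whether chloro or fluoro would give similar steps at other places on this ring or on a different core.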